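This account rests on a few compounds, and the source may have more. Where it says the series, first, only, none or still open, it means among the compounds named here.

Compound 1 `CCCN(C(=O)CC(=O)O)C1=C(C)CC(c2ccccc2)N(CCCCN)C1=O`: in an assay on K562 cells for inhibition of integrin alpha-5/beta-1 (Homo sapiens) (on this read-out lower numbers stand for stronger inhibition and higher numbers for weaker inhibition), compound 1 gives 43 nM.
Compound 2 `CCCN(C(=O)CCN)C1=C(C)CC(c2ccccc2)N(CCC(=O)O)C1=O`: for compound 2 this assay reports only a limit, > 1000000 nM.
Compound 3 `CCCN(C(=O)CCCCCN)C1=C(C)CC(c2ccccc2)N(CCC(=O)O)C1=O`: for compound 3 the result is likewise a limit, > 1000000 nM.

Among the compounds with values here, compound 1 thus holds the only real number here; the other two results sit at the limit of > 1000000 nM in this assay, at which 2 of the 3 values shown sit. Within the data shown here, the single measured step, a step that the two limits leave unreadable from compound 2 to compound 3, cannot be read. Compound 4 `CCCN(C(=O)CC(=O)O)C1=C(C)CC(c2ccccc2)N(Cc2ccc(N)cc2)C1=O` differs from compound 1 by 4-aminophenyl in place of 3-aminopropyl on a saturated chain carbon bound to an amide-type nitrogen in a ring. Among the measured compounds shown here, no measured step touches this change, so there is nothing to point in either direction; the expectation is a step within the scatter, a 1.4-fold higher number from compound 1 to compound 4 (0.14 log units; within the scatter). Compound 4 is therefore estimated at 60 nM, between 12 nM and 300 nM.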

Compound 4, half-maximal inhibitory concentration: 170 nM
Beside the measured number, compound 4's estimate is 2.8-fold (0.45 log units) below it; low and high end bracket the measured number.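

In this assay, within the data shown here, there is a 4.0-fold higher number from compound 1 to compound 4 (0.60 log units; beyond the scatter) when 4-aminobutyl gives way to 4-aminobenzyl, the first readable step at this position. The amine-bearing group here can therefore hold a six-membered aromatic ring and still give a measurable number, though a weaker one. No measurement shown gives a reason for this step. Left open is how a guanidine in place of the amine, or a plain benzyl group with no amine, would read at this position.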